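Oxan-4-yl in place of pyrimidin-2-yl: working notes

The source may report more compounds than this note shows. Statements on the series, on what has been measured and on what is new or still open speak of the compounds shown alone.

Values in a functional assay on A2780 cells (Homo sapiens) for antiproliferative activity, read by CellTiter-Glo, with a stated time of 72 h (on this read-out higher numbers stand for weaker inhibition and lower numbers for stronger inhibition), so far
- compound 1 `C[C@H](NC(=O)C1CCOCC1)c1ccc(NC(=O)N2CC(c3cccnc3)C2)cc1` gives 17 nM
- compound 2 `C[C@H](NC(=O)c1cccc(F)c1)c1ccc(NC(=O)N2CC(c3ccc(N)nc3)C2)cc1` gives 7.6 nM
- compound 3 `C[C@H](NC(=O)c1ncccn1)c1ccc(NC(=O)N2CC(c3ccc(N)nc3)C2)cc1` gives 68 nM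

Compound 3 (68 nM) has the highest number of the three, beyond the scatter from both others. Not yet measured is compound 4 `C[C@H](NC(=O)C1CCOCC1)c1ccc(NC(=O)N2CC(c3ccc(N)nc3)C2)cc1` with oxan-4-yl in place of pyrimidin-2-yl on a carbonyl carbon. Among the measured compounds shown here, one measured step touches this place: an 8.9-fold higher number from compound 2 to compound 3 (0.95 log units; beyond the scatter) with pyrimidin-2-yl in place of 3-fluorophenyl, so pyrimidin-2-yl sits on the higher number of that pair. Compound 1 (17 nM) also carries oxan-4-yl on the carbonyl carbon, though its core differs from that of compound 3. This is thin evidence, but together it points to a lower number in this assay, by somewhat less than the measured step. The expected change is a 4.5-fold lower number from compound 3 to compound 4 (0.66 log units; beyond the scatter) and would lie beyond the scatter. The estimate for compound 4 is 15 nM with an expected range (5 nM to 45 nM).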

Compound 4, half-maximal inhibitory concentration in the A2780 assay: 46 nM
Compound 4: the middle estimate sits 3.1-fold (0.49 log units) below what was measured; the whole stated range lies below it.
By their numbers in the A2780 assay, from the lowest: compound 2; then compound 1; then compounds 4 and 3 (each within the scatter of the next).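

On this carbonyl carbon of the shared core, the A2780 assay does not separate oxan-4-yl from pyrimidin-2-yl (a 1.5-fold lower number from compound 3 to compound 4 (0.17 log units; within the scatter)), whereas 3-fluorophenyl stands apart from oxan-4-yl (a 6.1-fold higher number from compound 2 to compound 4 (0.78 log units; beyond the scatter)); compound 2 gives 7.6 nM, compound 3 gives 68 nM and compound 4 gives 46 nM. Among the compounds shown here, with oxan-4-yl held constant, the A2780 assay gives the first reading of amino in place of hydrogen on an aromatic carbon (a 2.7-fold higher number from compound 1 to compound 4 (0.43 log units; beyond the scatter)), so the value of compound 1 does not carry over to the amino-bearing core. In a physicochemical assay for solubility, read by LC-MS, in phosphate buffer, with a stated time of 24 h, at pH 6.8 (on this read-out lower numbers stand for lower solubility and higher numbers for higher solubility), the same exchange of oxan-4-yl for pyrimidin-2-yl also stays within the scatter (a 1.0-fold higher number from compound 3 to compound 4 (0.01 log units; within the scatter)); compound 3 gives 300000 nM and compound 4 gives 310000 nM.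

Nothing at hand accounts for any of these steps. Still open, as far as these compounds go, is whether piperidin-4-yl or a longer alkyl chain on this carbonyl carbon would match oxan-4-yl or come closer to 3-fluorophenyl in the A2780 assay.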